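Azetidine in Place of Dimethylamine at the Amide Carbonyl

The compounds below may be only part of what the source reports. "The series", "measured", "known", "first", "only" and "open" are said of these compounds alone.

Measured so far:
Compound 1, `CN(C)C(=O)/C=C1\CCc2ccc(F)cc21`: 100%
Compound 2, `NC(=O)/C=C1\CCc2ccc(Br)cc21`: 100%

Of the compounds shown here, two have been tested in a functional assay on the whole organism with Mus musculus as the target, at a dose of 100 mg/kg by the intraperitoneal route; a lower number here means less inhibition, a higher number more inhibition at the dose given (going by the name of the read-out). Compound 1 gives 100% and compound 2 gives 100%; the two values are level at the digits reported, so no difference between them can be claimed within the scatter of this assay. The inhibition in this assay is therefore level between compound 1 and compound 2.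

Compound 3, `O=C(/C=C1\CCc2ccc(F)cc21)N1CCC1`, has not been measured yet. It differs from compound 1 in one place: azetidin-1-yl in place of dimethylamino on a carbonyl carbon. Among the compounds with values here, no step between measured compounds exists to calibrate this change, so the expected step from compound 1 to compound 3 is a number 5 percentage points lower from compound 1 to compound 3 (within the scatter), which is taken to lie within the scatter. Compound 3 is therefore estimated to give 95% in this assay, with a likely range from 75% to 100%.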

Compound 3, a percentage reported as inhibition, in the whole organism at one dose (the size of the read-out at that dose, not a potency): 33%
For compound 3 the middle estimate is 62 percentage points above the measured one; the measured number lies below the stated range.
By their numbers in this assay, from the lowest: compound 3; then compounds 1 and 2 (each within the scatter of the next).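

In this assay, azetidin-1-yl in place of dimethylamino on a carbonyl carbon gives a number 67 percentage points lower from compound 1 to compound 3 (beyond the scatter), so this position is not indifferent to the group it carries. Within the data shown here, this is the first step at this position, since compound 1 and compound 2 differ in more than one place and their level values say nothing about the change on their own. The groups that leave and enter match in hydrogen-bond donors, hydrogen-bond acceptors and net charge, and they differ in heavy atoms and in the four-membered ring, but nothing at hand says what lies behind the step.

The compounds shown leave open whether a pyrrolidin-1-yl or piperidin-1-yl group on the same carbonyl carbon would keep the level of compound 1 or share the fall of compound 3. They also leave open whether an open-chain diethylamino group would hold that level.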